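Naphthyl pyridine propanoate series: acid, amide, ester

This account rests on a few compounds, and the source may have more. Where it says the series, first, only, none or still open, it means among the compounds named here.

Measured so far:
compound 1 `O=C(O)CCc1ccncc1-c1ccc2ccccc2c1` — 50.5 nM
compound 2 `O=C(CCc1ccncc1-c1ccc2ccccc2c1)N1CCOCC1` — 45.5 nM
compound 3 `CN1CCN(c2ccc(Nc3cnccc3/C=C/C(N)=O)cc2)CC1` — "not determined" (no result reported)

In an assay on a protein complex for inhibition of CDK8/Cyclin C (Homo sapiens), with a stated time of 1 h (a lower number here means a stronger inhibitor, a higher number a weaker inhibitor), compound 1 gives 50.5 nM and compound 2 gives 45.5 nM; the two values lie within the scatter of each other, as the step of a 1.1-fold lower number from compound 1 to compound 2 (0.05 log units; within the scatter) shows. Compound 3 `CN1CCN(c2ccc(Nc3cnccc3/C=C/C(N)=O)cc2)CC1` gives "not determined" (no result reported) in this assay, so it carries no number there.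

Compound 4 `CCOC(=O)/C=C/c1ccncc1-c1ccc2ccccc2c1` is not yet measured. It differs from compound 1 by 2-(ethoxycarbonyl)ethenyl in place of 2-carboxyethyl on an aromatic carbon. Among the compounds with values here, the only measured step that bears on this is a 1.1-fold lower number from compound 1 to compound 2 (0.05 log units; within the scatter), which changes the carbonyl substituent without moving the number beyond the scatter. Nothing measured covers the double bond that enters. On that basis the expected step is a 1.6-fold higher number from compound 1 to compound 4 (0.20 log units; within the scatter), not clearly beyond the scatter, with the range held wide. Compound 4 is therefore estimated at 80 nM, between 25 nM and 250 nM.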

Compound 4, half-maximal inhibitory concentration: 53.3 nM
Compound 4: middle estimate off by 1.5-fold (0.18 log units), on the high side, within the range that was stated.
By their numbers in this assay, from the lowest: compounds 2, 1 and 4 (each within the scatter of the next).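

Placing 2-(ethoxycarbonyl)ethenyl in place of 2-carboxyethyl on this aromatic carbon, ortho to a large group, gives a step that stays within the scatter in this assay (a 1.1-fold higher number from compound 1 to compound 4 (0.02 log units; within the scatter)). The earlier pair changed only the carbonyl substituent, whereas here the hydrogen-bond donor goes and a double bond enters, with no shift beyond the scatter. Nothing measured speaks to the reason for this. Still open, going by these compounds, is how the double bond and the ethyl ester each count alone. Also open, on these data alone, is whether an amine or a longer chain at this carbon would stay within the scatter of compound 1.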